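Swapping a Phenyl for a Dienyl Chain

The source may report more compounds than this note shows. Statements on the series, on what has been measured and on what is new or still open speak of the compounds shown alone.

Compound 1 `Cn1cncc1C(OCc1ccc(C#N)cc1C#Cc1ccccc1)c1ccc(C#N)cc1` gives 0.1 nM in a functional assay on NIH3T3 cells (Mus musculus); on this read-out lower numbers stand for an effect already at smaller amounts and higher numbers for an effect only at larger amounts of compound.
Compound 2 `Cn1cncc1C(OCc1ccc(C#N)cc1-c1ccccc1)c1ccc(C#N)cc1` gives 140 nM in this assay.
Compound 3 `Cn1cncc1C(OCc1ccc(C#N)cc1C#Cc1ccc(-c2ccccc2)cc1)c1ccc(C#N)cc1` gives > 0.1 nM in this assay, which is a limit of the assay and not a number.

Compound 2 stands at the highest of the two numbers shown; its nearest neighbour is compound 1, and the gap is a 1400-fold higher number from compound 1 to compound 2 (3.15 log units; beyond the scatter). That step rests on a single change on the shared core. The step from compound 1 to compound 3 is a number no lower from compound 1 to compound 3 (the limit leaves the size open), so its size cannot be read, as the limit of > 0.1 nM in this assay, at which 1 of the 3 values shown sits, shows.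

Compound 4 `CCC/C=C/C=C/c1cc(C#N)ccc1COC(c1ccc(C#N)cc1)c1cncn1C` is not yet measured. It differs from compound 2 by hepta-1,3-dien-1-yl in place of phenyl on an aromatic carbon. Among the measured compounds shown here, the one step that bears on this place is the one from compound 1 to compound 2, where a group with a chain-like extension gave way to phenyl and the number rose greatly. Reversing the direction, putting a chain in place of phenyl, should lower the number, though a diene is not an ethynyl link, so the size is uncertain. For compound 4 the expected step is a 28-fold lower number from compound 2 to compound 4 (1.45 log units; beyond the scatter). Compound 4 is therefore estimated at 5 nM, between 0.3 nM and 100 nM.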

Compound 4, half-maximal effective concentration: 16.7 nM
Estimate against measurement, compound 4: 3.3-fold (0.52 log units) below; measured number inside the range.
By their numbers in this assay, from the lowest: compound 1; then compound 4; then compound 2.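

In this assay, this position, ortho to a large group, does not depend on a ring: hepta-1,3-dien-1-yl in place of phenyl gives an 8.4-fold lower number from compound 2 to compound 4 (0.92 log units; beyond the scatter). The open chain still falls well short of the 2-phenylethynyl group, with a 170-fold higher number from compound 1 to compound 4 (2.22 log units; beyond the scatter), so it recovers only part of the difference between that group and phenyl. The value of compound 3 is a limit and its step cannot be read, and nothing shown accounts for the two new steps.

Going by these compounds, it remains open whether the double bonds matter or the length of the chain alone counts, a question that a saturated heptyl chain at this position would address. On these data alone, it is also open how a shorter chain, or a chain ending in an amine or a carboxylic acid, would fare here.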